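Swapping the styryl arm of compound 3 for a fluorophenyl

A few compounds are considered here, and "the series" means these few. Any claim that something is new, unique, unknown or untested is made for them only; others in the source may bear on it.

Three hydrazones sharing one naphthyloxyacetyl core have been measured in an ADME assay on HEL cells (Homo sapiens) for cytotoxicity; on this read-out higher numbers stand for lower toxicity in this test and lower numbers for higher toxicity in this test. Compound 1 `O=C(COc1cccc2ccccc12)N/N=C/c1ccc(O)cc1` gives 60.6 ug/mL. Compound 2 `O=C(COc1cccc2ccccc12)N/N=C/c1ccc(Cl)cc1` gives 100 ug/mL, and compound 3 `O=C(COc1cccc2ccccc12)N/N=C/C=C/c1ccccc1` gives 100 ug/mL. Going by the values given here, compound 3 therefore stands level with compound 2 at the digits printed, the two together giving the highest numbers of the three, while the remaining step is a 1.7-fold higher number from compound 1 to compound 3 (0.22 log units; within the scatter), so no compound can be called less toxic than another here.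

Compound 4 `O=C(COc1cccc2ccccc12)N/N=C/c1ccc(F)cc1` has not yet been tested. It differs from compound 3 in one place: 4-fluorophenyl in place of 2-phenylethenyl on a carbon with a double bond to nitrogen. Among the compounds with values here, the steps that bear on this are no change at the digits printed from compound 2 to compound 3 (within the scatter) and a 1.7-fold higher number from compound 1 to compound 2 (0.22 log units; within the scatter), both within the scatter, showing that neither the arm on the imine carbon nor a halogen on that aryl ring has moved the number beyond noise so far. He therefore expects the step of no change at the digits printed from compound 3 to compound 4 (within the scatter) to stay within the scatter, in no clear direction. Compound 4 is estimated at 100 ug/mL, within a range of 55 ug/mL to 160 ug/mL.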

Compound 4, half-maximal cytotoxic concentration: 71.6 ug/mL
For compound 4 the middle estimate is 1.4-fold (0.15 log units) above the measured one, within the range that was stated.
By their numbers in this assay, from the lowest: compounds 1, 4, 2 and 3 (each within the scatter of the next).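

At the carbon with a double bond to nitrogen, 4-fluorophenyl in place of 2-phenylethenyl gives in this assay a step of a 1.4-fold lower number from compound 3 to compound 4 (0.15 log units; within the scatter), so a second aryl arm carrying a halogen also stays within the noise against the styryl arm. On the aromatic carbon, fluoro in place of chloro gives a 1.4-fold lower number from compound 2 to compound 4 (0.15 log units; within the scatter), and fluoro in place of hydroxy gives a 1.2-fold higher number from compound 1 to compound 4 (0.07 log units; within the scatter), so neither swap at this site separates the compounds, and none of the four can be called less toxic than another. Nothing available bears on what lies behind these small steps.

As far as these compounds go, whether an amine or a carboxylic acid on that aryl ring would move the number beyond the scatter remains open. So does the effect of a longer chain in place of the 2-phenylethenyl arm, or of any change to the shared core.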